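A few compounds are considered here, and "the series" means these few. Any claim that something is new, unique, unknown or untested is made for them only; others in the source may bear on it.

Compound 1 `O=C(Nc1ccccc1)[C@@H]1CCCN1C(=O)CSc1nc2ccccc2[nH]1` gives 560 nM in an assay on CHO cells for displacement of a labelled ligand from Orexin receptor type 2 (Homo sapiens); on this read-out lower numbers stand for stronger inhibition and higher numbers for weaker inhibition. Compound 3 `O=C(Nc1ccccc1-c1ccccc1)[C@@H]1CCCN1C(=O)CSc1nc2ccccc2[nH]1` carries phenyl in place of hydrogen on an aromatic carbon and gives 0.6 nM; the corresponding step is a 930-fold lower number from compound 1 to compound 3 (2.97 log units; beyond the scatter). Compound 2 `Cn1c(SCC(=O)N2CCC[C@H]2C(=O)Nc2ccccc2-n2cccc2)nc2ccccc21` gives 0.3 nM. Compound 3 thus stands second highest of the three numbers in this assay, with compound 2 nearest and within the scatter, and compound 1 far higher, beyond the scatter.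

Compound 4 `Cn1c(SCC(=O)N2CCC[C@H]2C(=O)Nc2ccccc2-c2ccccc2)nc2ccccc21` differs from compound 3 by methyl in place of hydrogen on an aromatic nitrogen. Among the compounds with values here, no measured step covers this change on its own: the single measured step, from compound 1 to compound 3, concerns a different position. Compound 2 carries the same methyl on the aromatic nitrogen but differs from compound 3 in a second place as well, so the values of compound 2 and compound 3 show only that the two lie within the scatter of each other. The step from compound 3 to compound 4 is therefore expected to be a 1.2-fold lower number from compound 3 to compound 4 (0.08 log units; within the scatter), within the scatter. Compound 4 is estimated at 0.5 nM, between 0.15 nM and 1.5 nM.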

Compound 4, inhibition constant: 0.2 nM
Compound 4: middle estimate off by 2.5-fold (0.40 log units), on the high side, and the stated range covers the measured number.
By their numbers in this assay, from the lowest: compounds 4, 2 and 3 (each within the scatter of the next, the first and the last beyond it); then compound 1.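

In this assay, the change from 1H-benzimidazol-2-yl to 1-methyl-1H-benzimidazol-2-yl now has a step of its own: a 3.0-fold lower number from compound 3 to compound 4 (0.48 log units; beyond the scatter), modest in size, so methyl can replace the hydrogen on this aromatic nitrogen with no loss on this read-out. With that methyl present in both compounds, phenyl in place of 1H-pyrrol-1-yl on an aromatic carbon gives a 1.5-fold lower number from compound 2 to compound 4 (0.18 log units; within the scatter), so the two groups cannot be told apart here. Nothing at hand offers a reason for the methyl step.

The compounds shown leave open whether the same methyl step holds with 1H-pyrrol-1-yl, or with the unsubstituted phenyl amide of compound 1. Also open, on these data alone, is how this nitrogen responds to an ethyl group, a longer chain, or a chain ending in an amine or a carboxylic acid.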